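Chloro to Fluoro on the Phenyl Ring: Expected Exposure

The source may hold more compounds than are shown below. What is called first, only, known or untested is meant among the compounds shown, and "the series" means these compounds.

Of the compounds shown here, three sharing one core have been measured in an ADME assay on the whole organism (Rattus norvegicus, strain Sprague-Dawley) for pharmacokinetics, read by LC-MS, with a stated time of 24 h, at a dose of 1 mg/kg by the intravenous route; on this read-out higher numbers stand for higher exposure at the dose given and lower numbers for lower exposure. Compound 1 `CN1CCC(=C(F)c2cccc(NC(=O)c3ccc(F)cn3)n2)CC1` gives 103 ng.h/mL. Compound 2 `CN1CCC(=C(F)c2cccc(NC(=O)c3ccc(Cl)cc3F)n2)CC1` gives 90.5 ng.h/mL. Compound 3 `CN1CCC(=C(F)c2cccc(NC(=O)c3ccc(Cl)cc3)n2)CC1` gives 89.4 ng.h/mL, the lowest of the three numbers, though its gaps to the other two are within the scatter. The steps measured so far all change the ring attached to the carbonyl carbon: a 1.1-fold lower number from compound 1 to compound 2 (0.06 log units; within the scatter), a 1.2-fold lower number from compound 1 to compound 3 (0.06 log units; within the scatter) and a 1.0-fold lower number from compound 2 to compound 3 (0.01 log units; within the scatter). None of them moved this assay beyond the scatter.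

Compound 4 `CN1CCC(=C(F)c2cccc(NC(=O)c3ccc(F)cc3)n2)CC1` differs from compound 3 by fluoro in place of chloro on an aromatic carbon, a small swap of one halogen for another at the same spot. Given that the larger ring swaps from compound 1 and the loss of fluoro from compound 2 left this assay essentially unchanged, no step beyond the scatter is expected here either, and compound 4 is estimated to give 90 ng.h/mL, with a likely range from 45 ng.h/mL to 180 ng.h/mL, meaning an expected step of a 1.0-fold higher number from compound 3 to compound 4 (0.00 log units; within the scatter).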

Compound 4, area under the concentration-time curve: 104 ng.h/mL
Compound 4: the middle estimate sits 1.2-fold (0.06 log units) below what was measured; the measured number falls inside the stated range.
By their numbers in this assay, from the lowest: compounds 3, 2, 1 and 4 (each within the scatter of the next).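

Changing only the halogen at this spot, para to a large group, gives a 1.2-fold higher number from compound 3 to compound 4 (0.07 log units; within the scatter) in this assay and so the chloro and fluoro forms cannot be told apart here. The comparisons with the other two compounds read the same way, with a 1.1-fold higher number from compound 2 to compound 4 (0.06 log units; within the scatter) and with a 1.0-fold higher number from compound 1 to compound 4 (0.00 log units; within the scatter) as well, so 4-fluorophenyl on the carbonyl carbon is not distinguished from 4-chloro-2-fluorophenyl or from 5-fluoropyridin-2-yl. No measurement on hand says why exposure stays so level across these swaps.

Only chloro and fluoro stand at this spot in the compounds shown, so whether a methoxy group, an amine or a nitrile there would move this assay beyond the scatter remains open. Also open, going by these compounds, is whether the same flat picture would hold on a changed core, since all four compounds share one.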